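Pyridin-3-yl in Place of Bromophenyl on the Dienone

The compounds below may be only part of what the source reports. "The series", "measured", "known", "first", "only" and "open" are said of these compounds alone.

Compound 1 `CC1=C(/C=C/C(=O)/C=C/c2ccc(Br)cc2)C(C)(C)CCC1` holds the lowest of the two numbers measured in a functional assay on IMR-32 cells (Homo sapiens) for cytotoxicity, read by sulforhodamine B assay, with a stated time of 48 h (on this read-out higher numbers stand for weaker inhibition and lower numbers for stronger inhibition), where compound 1 gives 10400 nM. Compound 2 `CC1=C(/C=C/C(=O)/C=C/c2ccc(Cl)c(Cl)c2)C(C)(C)CCC1` gives 72400 nM in this assay, a number that lies beyond the scatter above the number of compound 1. Compound 3 `CC1=C(/C=C/C(=O)/C=C/c2cccnc2)C(C)(C)CCC1` has not been measured; it differs from compound 1 by pyridin-3-yl in place of 4-bromophenyl on a double-bonded chain carbon bound to a double-bonded chain carbon. Among the compounds with values here, no measured pair shows what this change does. The step of a 2.4-fold higher number from compound 1 to compound 3 (0.38 log units; beyond the scatter) is expected to weaken inhibition somewhat, though the shown compounds cannot fix its size. Compound 3 is therefore estimated at 25000 nM, within a range from 6000 nM to 100000 nM.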

Compound 3, half-maximal inhibitory concentration: 25300 nM
Estimate against measurement, compound 3: 1.0-fold (0.01 log units) below; low and high end bracket the measured number.
By their numbers in this assay, from the lowest: compound 1; then compound 3; then compound 2.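

In this assay, the change from 4-bromophenyl to pyridin-3-yl gives a 2.4-fold higher number from compound 1 to compound 3 (0.39 log units; beyond the scatter), so this place on the chain tolerates a ring with a hetero atom, with a modest loss of inhibition. This single change removes the bromine and brings in a ring nitrogen together, so the step cannot divide its size between the two. No measurement is available that explains the step.

Still open, going by these compounds, is how a phenyl ring carrying an amine or a carboxylic acid would behave at this place. On these data alone, whether pyridin-4-yl would match pyridin-3-yl also remains unknown.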